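Morpholin-4-yl for anilino on the amide carbonyl

The compounds below may be only part of what the source reports. "The series", "measured", "known", "first", "only" and "open" are said of these compounds alone.

Measured so far in a functional assay on PC-3 cells (Homo sapiens) for inhibition, read by sulforhodamine B assay, with a stated time of 72 h; a higher number here means a weaker inhibitor, a lower number a stronger inhibitor (compound 2 as a limit only):
Compound 1 `Nc1sc(-c2ccc(Cl)cc2)c(-c2ccc(Cl)cc2)c1C(=O)NC1CCC1` gives 24800 nM
Compound 2 `Nc1sc(-c2ccc(Cl)cc2)c(-c2ccc(Cl)cc2)c1C(=O)Nc1ccccc1` gives > 50000 nM

For compound 2, the reading > 50000 nM is only a limit of this assay and not a number. Compound 3 `Nc1sc(-c2ccc(Cl)cc2)c(-c2ccc(Cl)cc2)c1C(=O)N1CCOCC1` carries morpholin-4-yl in place of anilino on a carbonyl carbon. Among the compounds with values here, one measured step bears on this place (an at least 2.0-fold higher number from compound 1 to compound 2 (0.30 log units; that floor lies within the scatter)), with phenyl in place of cyclobutyl on an amide-type nitrogen. Its size is known only as a floor, and it gives no direction for the new exchange. Within the data shown here, with that step as the only guide, no change beyond the scatter is expected (an at least 1.1-fold lower number from compound 2 to compound 3 (0.04 log units; that floor lies within the scatter)). Compound 3 is estimated at 45000 nM in this assay, with 20000 nM to 90000 nM as the expected range.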

Compound 3, half-maximal inhibitory concentration: 11700 nM
Beside the measured number, compound 3's estimate is 3.8-fold (0.59 log units) above it; the measured number lies below the stated range.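

In this assay, the group on the carbonyl carbon now moves the reading beyond the scatter, which the first pair could not establish. Morpholin-4-yl in place of anilino gives an at least 4.2-fold lower number from compound 2 to compound 3 (0.63 log units; beyond the scatter), and morpholin-4-yl in place of cyclobutylamino gives a 2.1-fold lower number from compound 1 to compound 3 (0.33 log units; beyond the scatter), so compound 3 is the strongest of the three. Compound 2 stands at a limit of the assay and not at a number, so the first of these steps is a floor only: the limit of > 50000 nM in this assay, at which 1 of the 3 values shown sits.

The compounds shown do not separate the part played by the ring oxygen of morpholin-4-yl from the loss of the amide hydrogen. Piperidin-1-yl, which lacks that oxygen, and dimethylamino, an open-chain amine, on the same carbonyl carbon remain open.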